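Bromine for chlorine on the ring of compound 1

This account rests on a few compounds, and the source may have more. Where it says the series, first, only, none or still open, it means among the compounds named here.

The series is small. Compound 1 `Cc1ccc(S(=O)(=O)N2CC[C@@H](Cl)C[C@@H]2CC(C)C)cc1` is tested in a functional assay on WiDr cells (Homo sapiens) for antiproliferative activity, read by sulforhodamine B assay, with a stated time of 48 h (a lower number here means a stronger inhibitor of growth, a higher number a weaker inhibitor of growth), where compound 1 gives 22000 nM. Going by the values given here, its only measured neighbour is compound 2 `CCCCCCC[C@H]1C[C@H](Cl)CCN1S(=O)(=O)c1ccc(C)cc1`, which in this assay gives 54000 nM; the change from compound 1 to compound 2 is a longer chain, and it brings a 2.5-fold higher number from compound 1 to compound 2 (0.39 log units; beyond the scatter). Among the two measured numbers, compound 1 stands at the lower end.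

Compound 3 `Cc1ccc(S(=O)(=O)N2CC[C@@H](Br)C[C@@H]2CC(C)C)cc1` differs from compound 1 in a different place: bromo in place of chloro on a saturated ring carbon. Among the compounds with values here, no measured step touches the halogen on the ring, so the single known step, which concerns the chain, does not bear on this change. With nothing that speaks for a shift in either direction, the expectation for compound 3 is a number close to that of compound 1, and the step from compound 1 to compound 3 is expected to be a 1.1-fold lower number from compound 1 to compound 3 (0.04 log units; within the scatter). Compound 3 is therefore estimated at 20000 nM, within a range from 8000 nM to 50000 nM.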

Compound 3, concentration for 50% growth inhibition: 14000 nM
Compound 3: middle estimate off by 1.4-fold (0.15 log units), on the high side, within the range that was stated.
By their numbers in this assay, from the lowest: compounds 3 and 1 (each within the scatter of the next); then compound 2.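

In this assay, going by these compounds alone, bromo in place of chloro on the saturated ring carbon gives a 1.6-fold lower number from compound 1 to compound 3 (0.20 log units; within the scatter), the first measured step at this position. Compounds 1 and 3 therefore read alike, and the two halogens cannot be told apart here, whereas the change in the chain gave a 2.5-fold higher number from compound 1 to compound 2 (0.39 log units; beyond the scatter). Nothing among the data explains why the two halogens read alike.

As far as these compounds go, both halogens belong to the same family, so it remains open whether fluoro, a hydroxyl or an amine on this ring carbon would also leave the number where compound 1 and compound 3 lie. From the compounds shown here alone, it is also open whether bromo in place of chloro would read the same on the longer chain of compound 2.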